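Changing the Nitrogen Substituent on a Weak Antiproliferative Compound

The compounds below may be only part of what the source reports. "The series", "measured", "known", "first", "only" and "open" are said of these compounds alone.

In a functional assay on HCT-116 cells (Homo sapiens) for antiproliferative activity, read by MTT assay, with a stated time of 48 h (a higher number here means a weaker inhibitor, a lower number a stronger inhibitor), compound 1 (`COc1ccc(-c2c(Nc3ccc(C)c(O)c3)c3ccccc3oc2=O)cc1`) gives 12300 nM and compound 3 (`COc1ccc(-c2c(Nc3ccc(C)c(O)c3)c3ccc(OC)cc3oc2=O)cc1`) gives 26500 nM as the higher of the two numbers, so compound 3 is the weaker inhibitor. Compound 2 (`COc1ccc(-c2c(Nc3ccc(F)cc3)c3ccc(OC)cc3oc2=O)cc1`) has the entry "not determined" (no result reported) and offers no number. For the measured compounds named here, the only measured step is a 2.2-fold higher number from compound 1 to compound 3 (0.33 log units; beyond the scatter) with methoxy in place of hydrogen on an aromatic carbon, which is a different change. Compound 4 (`CCOc1ccc(Nc2c(-c3ccc(OC)cc3)c(=O)oc3cc(OC)ccc23)cc1`) has 4-ethoxyphenyl in place of 3-hydroxy-4-methylphenyl on a nitrogen on an aromatic ring. Going by the values given here, no measured step covers this swap, so in this assay no step beyond the scatter is expected in either direction, and the estimate stays anchored on compound 3 at 26500 nM as the closest measurement. The expected step is a 1.1-fold higher number from compound 3 to compound 4 (0.05 log units; within the scatter) and remains uncertain. Compound 4 is estimated at 30000 nM with an expected range from 10000 nM to 90000 nM in this measurement.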

Compound 4, half-maximal inhibitory concentration: 33000 nM
For compound 4 the middle estimate is 1.1-fold (0.04 log units) below the measured one; the range from low to high includes it.
By their numbers in this assay, from the lowest: compound 1; then compounds 3 and 4 (each within the scatter of the next).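

In this assay, putting 4-ethoxyphenyl in place of 3-hydroxy-4-methylphenyl on the nitrogen gives a 1.2-fold higher number from compound 3 to compound 4 (0.10 log units; within the scatter) and so leaves the two compounds indistinguishable. The entering group has 0 hydrogen-bond donors and the leaving group has 1, so in this pair the hydroxy group is not needed to hold activity at this weak level. Nothing available here explains why the swap makes so little difference.

From the compounds shown here alone, it remains open whether an amine or a carboxylic acid on this aromatic ring, or a chain longer than ethoxy, would give a stronger inhibitor.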